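From a butyl chain to an oxan-2-yl ring

This account rests on a few compounds, and the source may have more. Where it says the series, first, only, none or still open, it means among the compounds named here.

In a functional assay, read by fluorescence and spectrophotometry, with a stated time of 1 h (on this read-out higher numbers stand for an effect only at larger amounts of compound and lower numbers for an effect already at smaller amounts), compound 1 (`C=CCCCCCCS(=O)(=O)/C=C/c1ccc(O)c(O)c1`) gives 6400 nM, compound 2 (`O=S(=O)(/C=C/c1ccc(O)c(O)c1)CC1CCCCC1`) gives 7500 nM and compound 3 (`CCCCCS(=O)(=O)/C=C/c1ccc(O)c(O)c1`) gives 8100 nM. Compound 3 therefore stands with the other two, all within the usual scatter of repeated measurements.

Compound 4 (`O=S(=O)(/C=C/c1ccc(O)c(O)c1)CC1CCCCO1`) differs from compound 3 on a saturated chain carbon bound to a sulfonyl sulfur: oxan-2-yl in place of butyl on a saturated chain carbon bound to a sulfonyl sulfur. The closest comparison is a 1.1-fold higher number from compound 2 to compound 3 (0.03 log units; within the scatter), where butyl replaces cyclohexyl, the other ring-bearing group. The remaining comparisons, a 1.2-fold higher number from compound 1 to compound 2 (0.07 log units; within the scatter) and a 1.3-fold higher number from compound 1 to compound 3 (0.10 log units; within the scatter), are equally small. Changing this side group has so far left the number within the scatter, whether it carries a chain or a ring. However, none of the three measured compounds has a hydrogen-bond acceptor in this group, so the data cannot show what one would do.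

No step beyond the scatter is expected in this assay, and the expected change is a 1.0-fold lower number from compound 3 to compound 4 (0.01 log units; within the scatter). For compound 4, the estimated value is 8000 nM, with an expected range from 4000 nM to 16000 nM.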

Compound 4, half-maximal effective concentration: 10800 nM
For compound 4 the middle estimate is 1.4-fold (0.13 log units) below the measured one, and the stated range covers the measured number.
By their numbers in this assay, from the lowest: compounds 1, 2, 3 and 4 (each within the scatter of the next).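

For the compounds shown here, compound 4 is the first compound here with a hydrogen-bond acceptor in this side group, and in this assay swapping butyl for oxan-2-yl stays within the usual scatter (a 1.3-fold higher number from compound 3 to compound 4 (0.12 log units; within the scatter)). The picture is the same when oxan-2-yl is compared with the cyclohexyl of compound 2 (a 1.4-fold higher number from compound 2 to compound 4 (0.16 log units; within the scatter)) and with the hept-6-en-1-yl of compound 1 (a 1.7-fold higher number from compound 1 to compound 4 (0.23 log units; within the scatter)), so across these four compounds, a ring oxygen in this group joins chains and an all-carbon ring without a step beyond the scatter; no measurement is available that would explain this result.

The compounds shown leave open whether an amine or a carboxylic acid on this saturated chain carbon would produce a step beyond the scatter. They also leave open whether any side group here would matter on a core other than the shared one.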